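The source may report more compounds than this note shows. Statements on the series, on what has been measured and on what is new or still open speak of the compounds shown alone.

Compound 3 `Cc1cc(C#N)cc(-c2c(C)nn(-c3nc(-c4ccc(Cl)c(Cl)c4)c(SC(C)C)s3)c2C(=O)O)c1` has the lowest number of the three in a functional assay on BJAB cells (Homo sapiens) for antiproliferative activity, with a stated time of 4 days (a lower number here means that less compound is needed, a higher number that more compound is needed for the effect), giving 4800 nM. Compound 1 `Cc1nn(-c2nc(-c3ccc(Cl)c(Cl)c3)c(SC(C)C)s2)c(C(=O)O)c1-c1cccc(Cl)c1C` gives 5100 nM, and the step of a 1.1-fold lower number from compound 1 to compound 3 (0.03 log units; within the scatter) stays within the scatter, so the two are not ranked against each other. Compound 2 `COc1ccccc1-c1c(C)nn(-c2nc(-c3ccc(Cl)c(Cl)c3)c(SC(C)C)s2)c1C(=O)O` gives 14700 nM, and the step of a 3.1-fold lower number from compound 2 to compound 3 (0.49 log units; beyond the scatter) is the one clear difference in this set. Compound 4 `Cc1nn(-c2nc(-c3ccc(Cl)c(Cl)c3)c(SC(C)C)s2)c(C(=O)O)c1-c1cncc(C#N)c1` differs from compound 3 by 5-cyanopyridin-3-yl in place of 3-cyano-5-methylphenyl on an aromatic carbon. The measured steps, a 2.9-fold higher number from compound 1 to compound 2 (0.46 log units; beyond the scatter) and a 1.1-fold lower number from compound 1 to compound 3 (0.03 log units; within the scatter), swap groups on a six-membered aromatic ring of carbon only and never bring in a ring with a hetero atom, so they bear on this step only loosely; a step in this assay no larger than the modest ones seen is expected. Compound 4 is estimated at 6000 nM, between 2500 nM and 14000 nM, which means an expected 1.3-fold higher number from compound 3 to compound 4 (0.10 log units; within the scatter).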

Compound 4, half-maximal effective concentration: 20000 nM
Compound 4: the middle estimate sits 3.3-fold (0.52 log units) below what was measured, and the stated range ends below it.
By their numbers in this assay, from the lowest: compounds 3 and 1 (each within the scatter of the next); then compounds 2 and 4 (each within the scatter of the next).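

In this assay this position does not take the change to a ring with a hetero atom without a shift: 5-cyanopyridin-3-yl in place of 3-cyano-5-methylphenyl, with the nitrile kept, gives a 4.2-fold higher number from compound 3 to compound 4 (0.62 log units; beyond the scatter) and in place of 3-chloro-2-methylphenyl gives a 3.9-fold higher number from compound 1 to compound 4 (0.59 log units; beyond the scatter) while in place of 2-methoxyphenyl it gives only a 1.4-fold higher number from compound 2 to compound 4 (0.13 log units; within the scatter) within the scatter. Nothing available explains these steps. As far as these compounds go, the step from compound 3 to compound 4 changes the ring atom and removes the methyl together, so their separate shares stay open, as does whether an amine in place of the nitrile would hold up on the pyridine ring.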